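A few compounds are considered here, and "the series" means these few. Any claim that something is new, unique, unknown or untested is made for them only; others in the source may bear on it.

Compound 1 `CC(/C=C/c1ccc(Cl)cc1)=N\O` and compound 3 `CC(/C=C/c1cccc(Cl)c1)=N\O` were both tested in a functional assay on HEK293 cells for agonist activity at transient receptor potential cation channel subfamily A member 1 (Homo sapiens), read by scintillation counting and calcium flux; on this read-out higher numbers stand for an effect only at larger amounts of compound and lower numbers for an effect already at smaller amounts. There compound 1 gives 27600 nM, and compound 3 gives 63100 nM; both numbers are large, so each works only at high amounts. Compound 2 `O/N=C/C=C/c1ccccc1` belongs to the same family, but in this assay compound 2 gives "not determined" (no result reported), so it cannot be placed among these numbers. Compound 4 `CN(C)c1ccc(/C=C/C=N/O)cc1`, not yet measured, differs from compound 2 by dimethylamino in place of hydrogen on an aromatic carbon. Going by the values given here, no measured pair shows this change, so neither its size nor its direction can be read from the data. Compound 4 is expected to give roughly 30000 nM in this assay, most likely between 5000 nM and 100000 nM.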

Compound 4, half-maximal effective concentration: 15900 nM
Compound 4: middle estimate off by 1.9-fold (0.28 log units), on the high side, and the stated range covers the measured number.
By their numbers in this assay, from the lowest: compounds 4 and 1 (each within the scatter of the next); then compound 3.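

In this assay, going by these compounds alone, compound 2 carries no number, so no step from compound 2 to compound 4 can be read. As far as these compounds go, what dimethylamino in place of hydrogen does to the value stays open, and no supporting evidence bears on this result.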